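Swapping fluorines for hydroxyls on the hydrazone aryl

The source may hold more compounds than are shown below. What is called first, only, known or untested is meant among the compounds shown, and "the series" means these compounds.

Of the compounds shown here, three sharing one core have been tested in a functional assay on NCI-H460 cells (Homo sapiens) for cytotoxicity, read by MTT assay, with a stated time of 72 h; on this read-out higher numbers stand for weaker inhibition and lower numbers for stronger inhibition. Compound 1 `CN(C)CCn1cnnc1-c1cc(Oc2ccc(NC(=O)N/N=C/c3c(O)ccc4ccccc34)cc2F)ccn1` gives 890 nM. Compound 2 `Cc1cc(/C=N/NC(=O)Nc2ccc(Oc3ccnc(-c4nncn4CCN(C)C)c3)c(F)c2)cc(C)c1O` gives 2010 nM. Compound 3 `CN(C)CCn1cnnc1-c1cc(Oc2ccc(NC(=O)N/N=C/c3ccc(F)cc3F)cc2F)ccn1` gives 1930 nM, which places compound 3 second highest of the three numbers: the nearest step is a 1.0-fold lower number from compound 2 to compound 3 (0.02 log units; within the scatter), while the step of a 2.2-fold higher number from compound 1 to compound 3 (0.34 log units; beyond the scatter) sets it clearly apart from compound 1.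

Compound 4 `CN(C)CCn1cnnc1-c1cc(Oc2ccc(NC(=O)N/N=C/c3ccc(O)cc3O)cc2F)ccn1` is not yet measured. The change from compound 3 to compound 4 is 2,4-dihydroxyphenyl in place of 2,4-difluorophenyl on a carbon with a double bond to nitrogen.

Going by the values given here, two measured steps touch on this kind of change. The step of a 2.2-fold higher number from compound 1 to compound 3 (0.34 log units; beyond the scatter) shows that moving from a hydroxyl-bearing aromatic group to the 2,4-difluorophenyl weakened inhibition, whereas the step of a 2.3-fold higher number from compound 1 to compound 2 (0.35 log units; beyond the scatter) shows that a different hydroxyl-bearing phenyl weakened it by about the same amount. So a hydroxyl on the aryl group does not by itself guarantee a stronger result; the evidence points to a small or uncertain change. Compound 4 is therefore expected to land near compound 3, with an expected step of a 1.4-fold lower number from compound 3 to compound 4 (0.14 log units; within the scatter), leaning slightly toward stronger inhibition. For compound 4 the estimate is 1400 nM, with a likely range from 500 nM to 4000 nM.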

Compound 4, half-maximal inhibitory concentration: 11300 nM
The estimate for compound 4 lay 8.1-fold (0.91 log units) below the measured number, and the stated range ends below it.
By their numbers in this assay, from the lowest: compound 1; then compounds 3 and 2 (each within the scatter of the next); then compound 4.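

In this assay, going by these compounds alone, the group on the carbon with a double bond to nitrogen proves more sensitive than the earlier compounds could show: 2,4-dihydroxyphenyl in place of 2,4-difluorophenyl gives a 5.9-fold higher number from compound 3 to compound 4 (0.77 log units; beyond the scatter) and so weakens inhibition clearly, where the opening comparison gave no sign of such a drop. The same group also loses to the other two aryl groups, with a 5.6-fold higher number from compound 2 to compound 4 (0.75 log units; beyond the scatter) and the largest step of the series, a 13-fold higher number from compound 1 to compound 4 (1.10 log units; beyond the scatter), which makes compound 4 the weakest of the four. Compound 1 and compound 2 also carry a hydroxyl on their aryl groups yet stay well ahead of compound 4, so the presence of a hydroxyl alone does not track with weak inhibition here, and no measurement on these compounds accounts for the drop.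

Still open, from the compounds shown here alone, is whether the weak result needs both hydroxyls or appears with only one, as a 2-hydroxyphenyl or a 4-hydroxyphenyl group would show. A 2,4-dimethoxyphenyl group, with a methyl on each oxygen, or a 2,4-diaminophenyl group would test whether the hydroxyl hydrogens matter or whether other groups in the same places behave alike.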